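Bromo for fluoro on the shared core: compound 4

A few compounds are considered here, and "the series" means these few. Any claim that something is new, unique, unknown or untested is made for them only; others in the source may bear on it.

Three compounds of the series have numbers in a functional assay on COLO 205 cells (Homo sapiens) for inhibition, read by sulforhodamine B assay, with a stated time of 48 h; a lower number here means a stronger inhibitor, a higher number a weaker inhibitor. Compound 1 `O=C1C(=O)N(CCCCn2cc(COc3cc(=O)oc4ccccc34)nn2)c2ccc(F)cc21` gives 9110 nM. Compound 2 `O=C1C(=O)N(CCCn2cc(COc3cc(=O)oc4ccccc34)nn2)c2ccc(F)cc21`, which carries the shorter chain between the two ring systems, gives 8880 nM. Compound 3 `O=C1C(=O)N(CCCCn2cc(COc3cc(=O)oc4ccccc34)nn2)c2ccc(Cl)cc21` gives 13100 nM. Compound 2 has the lowest of the three numbers, but its gap to compound 1 and to compound 3 both lie within the scatter, so no order among the three can be claimed. Among the measured compounds shown here, the one single-point step measured so far is the halogen swap a 1.4-fold higher number from compound 1 to compound 3 (0.16 log units; within the scatter); it stays within the scatter.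

Compound 4 `O=C1C(=O)N(CCCn2cc(COc3cc(=O)oc4ccccc34)nn2)c2ccc(Br)cc21` differs from compound 2 in one place: bromo in place of fluoro on an aromatic carbon. For the measured compounds named here, the only step that bears on it is the chloro-for-fluoro exchange from compound 1 to compound 3 at the same aromatic carbon, which moved the number only within the scatter. A heavier halogen at this position has therefore given no step beyond the scatter in this assay, and nothing in the data points the other way for bromo. Compound 4 is expected to land near compound 2, with a 1.2-fold higher number from compound 2 to compound 4 (0.07 log units; within the scatter), estimated at 10500 nM within a range of 5500 nM to 21000 nM.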

Compound 4, half-maximal inhibitory concentration: 13000 nM
Estimate against measurement, compound 4: 1.2-fold (0.09 log units) below; the measured number falls inside the stated range.
By their numbers in this assay, from the lowest: compounds 2, 1, 4 and 3 (each within the scatter of the next).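

Bromo in place of fluoro on this aromatic carbon gives, in this assay, a 1.5-fold higher number from compound 2 to compound 4 (0.17 log units; within the scatter). The earlier halogen exchange at this carbon reached only chloro and only on the longer chain, with a 1.4-fold higher number from compound 1 to compound 3 (0.16 log units; within the scatter); the series now holds a second exchange, with a bromo group and on the shorter chain, and neither step lies beyond the scatter, so across these two pairs the choice among fluoro, chloro and bromo at this carbon gives no readable difference. No measurement is available that could explain this outcome or tie it to any property of the halogens.

The compounds shown carry only halogens at this carbon, so it remains open whether an amine, a carboxylic acid or a methoxy group there would give a step beyond the scatter in this assay. Also open is whether a longer chain than those shown between the two ring systems, or a change on the far side of the triazole-linked end of the molecule, would move the number more than the halogen exchanges have.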